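The source may hold more compounds than are shown below. What is called first, only, known or untested is meant among the compounds shown, and "the series" means these compounds.

Series notes. In an assay for binding affinity to Corticotropin releasing factor receptor (Rattus norvegicus) (on this read-out higher numbers stand for weaker inhibition and lower numbers for stronger inhibition), compound 1 `CCc1nc2c(-c3ccc(C(F)(F)F)cc3Cl)ccnc2n1C(CC)CCOC` gives 0.7 nM. Compound 3 `CCCC(C)n1c(CC)nc2c(-c3cc(C)c(OC)cc3C)ccnc21` gives 0.6 nM in this assay. Compound 2 `CCc1nc2c(-c3ccc(Cl)cc3Cl)ccnc2n1[C@H](CC)C1CC1` gives 0.2 nM in this assay, the lowest of the three numbers, with compound 3 nearest and compound 1 furthest, both gaps lying beyond the scatter. Compound 4 `CCc1nc2c(-c3ccc(Cl)cc3Cl)ccnc2n1[C@H](C)C1CC1` has not yet been measured in this assay; it differs from compound 2 by hydrogen in place of methyl on a saturated chain carbon, two bonds along the chain from an aromatic nitrogen and a saturated ring carbon, which cut one bond further out reads ethyl to methyl, 1-cyclopropylpropyl to 1-cyclopropylethyl. Going by the values given here, no measured pair in this set shows that change, so the size of the step rests on no direct data here. A small weakening is expected, with the step of a 1.8-fold higher number from compound 2 to compound 4 (0.24 log units; within the scatter) likely not beyond the scatter. Compound 4 is estimated at 0.35 nM, range 0.15 nM to 1 nM.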

Compound 4, inhibition constant: 0.6 nM
The estimate for compound 4 lay 1.7-fold (0.23 log units) below the measured number; the measured number falls inside the stated range.
By their numbers in this assay, from the lowest: compound 2; then compounds 3, 4 and 1 (each within the scatter of the next).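

In this assay, going by these compounds alone, cutting ethyl to methyl on this saturated chain carbon brings a 3.0-fold higher number from compound 2 to compound 4 (0.48 log units; beyond the scatter) and so gives the first direct reading at this position. A change of one carbon, with the rest of the molecule fixed, is enough to move the number beyond the scatter, and here 1-cyclopropylpropyl stands lower than 1-cyclopropylethyl. Nothing shown explains the step.

On these data alone, whether a longer chain such as propyl or butyl would lower the number further remains open. This single pair also cannot show whether the step holds with other groups on the core.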